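The source may report more compounds than this note shows. Statements on the series, on what has been measured and on what is new or still open speak of the compounds shown alone.

In a functional assay on HOS-TE85 cells (Homo sapiens) for inhibition, read by CCK-8 assay, with a stated time of 72 h (a higher number here means a weaker inhibitor, a lower number a stronger inhibitor), compound 1 (`CCN(CC)c1ccc(N2C(=O)CSC2c2cccc(C(=O)NCCCCc3ccccc3)c2)cc1`) gives > 1000 nM, which is a limit and not a number. Compound 2 (`COc1cccc(OC)c1N1C(=O)CSC1c1cccc(C(=O)NCCCCc2ccccc2)c1`) gives > 1000 nM, also a limit, so its position is defined only by that limit. The evidence so far is the limit of > 1000 nM in this assay, at which 2 of the 2 values shown sit. The next change leads to compound 3 (`CC(F)(F)c1cccc(N2C(=O)CSC2c2cccc(C(=O)NCCCCc3ccccc3)c2)c1`): a group of 10 heavy atoms (8 carbon, 2 fluorine; one six-membered aromatic ring of carbon only) in place of a group of 10 heavy atoms (8 carbon, 2 oxygen; one six-membered aromatic ring of carbon only), on an amide-type nitrogen in a ring, on an amide-type nitrogen in a ring. Among the compounds with values here, the only measured step at this place is a step that the two limits leave unreadable from compound 1 to compound 2. It gives no size or direction to carry over, and the expectation for compound 3 rests on this step and on the limit shared by compound 1 and compound 2. A large move in this assay is therefore not expected, and any direction is tentative. The expected step is a step that the limit leaves unreadable from compound 2 to compound 3. The estimated value for compound 3 is 2000 nM, with an expected range from 400 nM to 10000 nM.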

Compound 3, half-maximal inhibitory concentration: 29.1 nM
Compound 3: the middle estimate sits 69-fold (1.84 log units) above what was measured; the whole stated range lies above it.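

At the amide-type nitrogen in a ring, the aromatic group is not a silent position in this assay: the group with 8 carbon and 2 fluorine atoms gives an at least 34-fold lower number from compound 2 to compound 3 (1.53 log units; beyond the scatter) and an at least 34-fold lower number from compound 1 to compound 3 (1.53 log units; beyond the scatter). Compound 1 and compound 2 alone could not show this, as the step between them cannot be read. The two new steps are minimum sizes, and their full extent stays open: the limit of > 1000 nM in this assay, at which 2 of the 3 values shown sit.

Each new step replaces a whole aromatic group, so the fluorines cannot be separated from the other differences between these groups. From the compounds shown here alone, whether a trifluoromethyl, a nitrile or a single fluorine on the aromatic ring would hold the value of compound 3 remains open, as does the effect of an amine or a carboxylic acid in that group.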